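A few compounds are considered here, and "the series" means these few. Any claim that something is new, unique, unknown or untested is made for them only; others in the source may bear on it.

Measured in a functional assay on the whole organism (stomach) for inhibition, with Canis familiaris (Canis lupus familiaris) as the target, at a dose of 5 mg/kg by the intravenous route; on this read-out higher numbers stand for a stronger effect at the one dose given and lower numbers for a weaker effect:
compound 1 `CC(=O)c1c(C)nc2c(OCc3ccccc3)cccn12` gives 9%
compound 2 `CCOCc1c(C)nc2c(OCc3ccccc3)cccn12` gives 35%
compound 3 `CCSCc1c(C)nc2c(OCc3ccccc3)cccn12` gives 0%

Compound 3 stands lowest of the three numbers; its gap to compound 1 lies within the scatter, its gap to compound 2 beyond it. Compound 4 `CC(=O)OCc1c(C)nc2c(OCc3ccccc3)cccn12` is unmeasured and differs from compound 3 by acetoxy in place of ethylsulfanyl on a saturated chain carbon bound to an aromatic carbon. The step that bears most on this change is a number 35 percentage points lower from compound 2 to compound 3 (beyond the scatter), in which the group with oxygen on that chain carbon stood well above the group with sulfur. The step of a number 9 percentage points lower from compound 1 to compound 3 (within the scatter) shows only that acetyl and the sulfur group give numbers within the scatter. Acetoxy again places oxygen on that carbon, so a rise in this assay is expected, smaller than the full step seen. The expected step is a number 22 percentage points higher from compound 3 to compound 4 (beyond the scatter). For compound 4 the estimate is 22%, from 5% to 45%.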

Compound 4, a percentage reported as inhibition, in the whole organism at one dose (the size of the read-out at that dose, not a potency): 87%
Beside the measured number, compound 4's estimate is 65 percentage points below it; the whole stated range lies below it.
By their numbers in this assay, from the lowest: compounds 3 and 1 (each within the scatter of the next); then compound 2; then compound 4.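

In this assay, the ester on the saturated chain carbon bound to an aromatic carbon gives the highest number in the series, with acetoxy in place of ethylsulfanyl (a number 87 percentage points higher from compound 3 to compound 4 (beyond the scatter)). Oxygen on that carbon does not by itself account for this, since acetyl in place of ethyl on the same oxygen still adds a large step (a number 52 percentage points higher from compound 2 to compound 4 (beyond the scatter)). Acetoxymethyl in place of acetyl on the aromatic carbon also gives a large step (a number 78 percentage points higher from compound 1 to compound 4 (beyond the scatter)).

Going by these compounds, whether a free hydroxyl, an amine or a longer acyl chain such as propanoyloxy at this carbon would hold the number remains open. No evidence at hand explains the size of these steps.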